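From methyl to isopropyl on an amide-type nitrogen

This account rests on a few compounds, and the source may have more. Where it says the series, first, only, none or still open, it means among the compounds named here.

For the measured compounds named here, in a functional assay (aorta) with Rattus norvegicus as the target (a higher number here means that more compound is needed for the effect, a lower number that less compound is needed), compound 2 `CNC(=O)NCc1nc(-c2ccc(OC)cc2)c(-c2ccc(OC)cc2)s1` gives 15 uM and holds the higher of the two numbers so far, while compound 1 `COc1ccc(-c2nc(CNC(=O)CSc3ccccc3)sc2-c2ccc(OC)cc2)cc1` gives 4.2 uM on the same test. Compound 3 `COc1ccc(-c2nc(CNC(=O)NC(C)C)sc2-c2ccc(OC)cc2)cc1` differs from compound 2 by isopropyl in place of methyl on an amide-type nitrogen and carries isopropyl in place of methyl on an amide-type nitrogen. Going by the values given here, the one measured step is a 3.6-fold higher number from compound 1 to compound 2 (0.55 log units; beyond the scatter) and it is modest. It arrived at the methylamino group by a different swap on the same carbonyl carbon, so it guides only loosely. In this assay a smaller move to a lower number is expected, with a 1.5-fold lower number from compound 2 to compound 3 (0.18 log units; within the scatter) as the estimate. Compound 3 is estimated at 10 uM with an expected range from 3.5 uM to 30 uM in this test.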

Compound 3, concentration for half-maximal effect: 5.7 uM
Compound 3: the middle estimate sits 1.8-fold (0.24 log units) above what was measured, and the stated range covers the measured number.
By their numbers in this assay, from the lowest: compounds 1 and 3 (each within the scatter of the next); then compound 2.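

In this assay, the group on this amide-type nitrogen clearly matters, since isopropyl in place of methyl gives a 2.6-fold lower number from compound 2 to compound 3 (0.42 log units; beyond the scatter). Swapping (phenylsulfanyl)methyl for isopropylamino on the carbonyl carbon gives a 1.4-fold higher number from compound 1 to compound 3 (0.13 log units; within the scatter), so these two quite different groups cannot be told apart on this test. Nothing measured here gives a reason for either step. Going by these compounds, it remains open how a longer chain such as butyl, or a ring such as cyclohexyl, would read on this nitrogen, and whether the number would keep falling as the group grows beyond isopropyl.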